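Swapping the aryl group on the shared core of compound 3

The compounds below may be only part of what the source reports. "The series", "measured", "known", "first", "only" and "open" are said of these compounds alone.

Of the compounds shown here, three sharing one core have been measured in a functional assay on Caco-2 cells (Homo sapiens) for cytotoxicity, with a stated time of 48 h; on this read-out higher numbers stand for weaker inhibition and lower numbers for stronger inhibition. Compound 1 `N#Cc1ccc(-c2cc(COC(Cc3cn(C4CCN(Cc5ccc([N+](=O)[O-])cc5)CC4)nn3)c3ccc(Br)cc3)on2)cc1` gives 2000 nM. Compound 2 `O=[N+]([O-])c1ccc(CN2CCC(n3cc(CC(OCc4cc(-c5cccc(F)c5)no4)c4ccc(Br)cc4)nn3)CC2)cc1` gives 5000 nM. Compound 3 `N#Cc1cccc(-c2cc(COC(Cc3cn(C4CCN(Cc5ccc([N+](=O)[O-])cc5)CC4)nn3)c3ccc(Br)cc3)on2)c1` gives 3000 nM, which places compound 3 second highest of the three numbers, nearest to compound 1 and furthest from compound 2, both neighbours within the scatter.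

The next step leads to compound 4 `COc1ccccc1-c1cc(COC(Cc2cn(C3CCN(Cc4ccc([N+](=O)[O-])cc4)CC3)nn2)c2ccc(Br)cc2)on1`, which differs from compound 3 in one place: 2-methoxyphenyl in place of 3-cyanophenyl on an aromatic carbon.

Going by the values given here, the steps that bear on this change all concern the same aryl group on the shared core. a 1.5-fold higher number from compound 1 to compound 3 (0.18 log units; within the scatter) and a 1.7-fold lower number from compound 2 to compound 3 (0.22 log units; within the scatter) were both within the scatter, while a 2.5-fold higher number from compound 1 to compound 2 (0.40 log units; beyond the scatter) was the only step beyond it. Every change tried at this position has therefore moved the number only modestly, so for compound 4 no step beyond the scatter is expected in this assay; the expected step is a 1.2-fold higher number from compound 3 to compound 4 (0.07 log units; within the scatter). On that basis compound 4 is estimated at 3500 nM, with a range from 1500 nM to 8000 nM, a number that is expected rather than known.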

Compound 4, half-maximal inhibitory concentration: > 25000 nM
Compound 4: a limit, no number (the forecaster's own chance of this, stated with the estimate: 10%); at least 7.1-fold (0.85 log units) between middle value and limit.
By their numbers in this assay, from the lowest: compounds 1, 3 and 2 (each within the scatter of the next, the first and the last beyond it). At a limit, above all of these: compound 4.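

In this assay, compound 4 stands at a limit of the assay and not at a number: the limit of > 25000 nM in this assay, at which 1 of the 4 values shown sits. Across 4-cyanophenyl, 3-cyanophenyl and 3-fluorophenyl, this position on the aromatic carbon had shown only modest steps at most, whereas 2-methoxyphenyl gives an at least 8.3-fold higher number from compound 3 to compound 4 (0.92 log units; beyond the scatter), together with an at least 5.0-fold higher number from compound 2 to compound 4 (0.69 log units; beyond the scatter) and an at least 12-fold higher number from compound 1 to compound 4 (1.09 log units; beyond the scatter), the last of them large, so the position can respond far more strongly than the earlier compounds showed. The exchange of 3-cyanophenyl for 2-methoxyphenyl leaves the counts of heavy atoms, hydrogen-bond donors and hydrogen-bond acceptors unchanged, so those counts do not separate the two groups even though the read-out does.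

The compounds shown leave open whether this step goes with the methoxy group itself or with its place on the phenyl ring, a question that a 3-methoxyphenyl, 4-methoxyphenyl or 2-cyanophenyl group would address. They also leave open how an unsubstituted phenyl group or a 2-aminophenyl group would read at this position.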